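The source may hold more compounds than are shown below. What is called first, only, known or untested is meant among the compounds shown, and "the series" means these compounds.

In a functional assay on HepG2 cells (Homo sapiens) for cytotoxicity, read by MTT assay, with a stated time of 24 h (a lower number here means a stronger inhibitor, a higher number a weaker inhibitor), compound 1 `C/C(=N\OCC(=O)N[C@H](C(=O)N[C@@H](CCCCN)C(=O)N1CCC[C@H]1C(=O)N[C@@H](CCCCN)C(=O)NCC(N)=O)[C@@H](C)O)c1ccc(NC(=O)c2cc(Br)ccc2O)cc1` gives > 200000 nM, which is a limit of the assay and not a number. For the measured compounds named here, compound 2 `O=C(Nc1ccc(Cl)c(Cl)c1)c1cc(Br)ccc1O` is the only one of the measured compounds with a numerical reading, at 4100 nM. Compound 3 `C/C(=N\OCC(=O)NCC(=O)O)c1ccc(NC(=O)c2cc(Br)ccc2O)cc1`, which also carries a carboxy group, gives > 200000 nM, again a limit. Compound 4 `C/C(=N\OCC(=O)N[C@H](C(=O)N[C@@H](CCCCN)C(=O)N1CCC[C@H]1C(=O)N[C@@H](CCCCN)C(=O)NCC(=O)O)[C@@H](C)O)c1ccc(NC(=O)c2cc(Br)ccc2O)cc1` differs from compound 1 by hydroxy in place of amino on a carbonyl carbon, turning carbamoyl to carboxy (hydroxy in place of amino on a carbonyl carbon). Going by the values given here, no measured pair isolates this change. In this assay, no step beyond the usual scatter is expected, and the estimated step is a number no higher from compound 1 to compound 4 (the limit leaves the size open). Compound 4 is expected at 200000 nM, with an estimated range of 100000 nM to 400000 nM.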

Compound 4, half-maximal inhibitory concentration: 191000 nM
The estimate for compound 4 lay 1.0-fold (0.02 log units) above the measured number; low and high end bracket the measured number.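

In this assay, hydroxy in place of amino on a carbonyl carbon gives an at least 1.0-fold lower number from compound 1 to compound 4 (0.01 log units; that floor lies within the scatter). For the compounds shown here, this is the first reading of this change at this position, and compound 4 gives a true number, 191000 nM, so carboxy here shows no proven step beyond the scatter. The true size of the step stays open because compound 1 stands at a limit and not at a number: the limit of > 200000 nM in this assay, at which 2 of the 4 values shown sit.

As far as these compounds go, how a methyl ester, a primary amine or a shorter chain in this place would read remains open.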